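The source may report more compounds than this note shows. Statements on the series, on what has been measured and on what is new or still open speak of the compounds shown alone.

Measured so far in a functional assay on HL-60 cells (Homo sapiens) for antiproliferative activity, read by MTT assay, with a stated time of 72 h; on this read-out higher numbers stand for weaker inhibition and lower numbers for stronger inhibition
- compound 1 `COc1cc(C(=O)c2sc3ccccc3c2-c2ccc(C)cc2)cc(OC)c1OC` gives 1400 nM
- compound 2 `COc1ccc(-c2c(C(=O)c3cc(OC)c(OC)c(OC)c3)sc3ccccc23)cc1` gives 1600 nM
- compound 3 `COc1ccc(OC)c(-c2c(C(=O)c3cc(OC)c(OC)c(OC)c3)sc3ccccc23)c1` gives > 10000 nM as a limit

Compound 3 stands at > 10000 nM and this is a limit of the assay, not a number. Next comes compound 4 `COc1cc(C(=O)c2sc3ccccc3c2Nc2ccc(C)cc2)cc(OC)c1OC` with the change (4-methylphenyl)amino in place of 2,5-dimethoxyphenyl on an aromatic carbon in which (4-methylphenyl)amino replaces 2,5-dimethoxyphenyl on an aromatic carbon. The step of a 1.1-fold higher number from compound 1 to compound 2 (0.06 log units; within the scatter) shows little, while an at least 7.1-fold higher number from compound 1 to compound 3 (0.85 log units; beyond the scatter) and an at least 6.2-fold higher number from compound 2 to compound 3 (0.79 log units; beyond the scatter) both accompany the arrival of 2,5-dimethoxyphenyl. Going by the values given here, no measured step covers the amino link. Compound 4 loses that group and carries 4-methylphenyl like compound 1 at 1400 nM so a return towards that level is expected. In this assay the expected step is an at least 6.6-fold lower number from compound 3 to compound 4 (0.82 log units; beyond the scatter) towards stronger inhibition. For compound 4 the estimated value is 1500 nM with an expected range from 300 nM to 8000 nM as the working figure.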

Compound 4, half-maximal inhibitory concentration: 4600 nM
Beside the measured number, compound 4's estimate is 3.1-fold (0.49 log units) below it, within the range that was stated.
By their numbers in this assay, from the lowest: compounds 1 and 2 (each within the scatter of the next); then compound 4. At a limit, above all of these: compound 3.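

In this assay, going by these compounds alone, the first change of link at this position, two ring bonds from the ring sulfur, leaves measurable activity but costs something against the direct aryl groups: a 3.3-fold higher number from compound 1 to compound 4 (0.52 log units; beyond the scatter) and a 2.9-fold higher number from compound 2 to compound 4 (0.46 log units; beyond the scatter). The amino link is therefore tolerated, though in this pair of comparisons it gives weaker inhibition. Compound 3 is held only at a limit, so an at least 2.1-fold lower number from compound 3 to compound 4 (0.33 log units; beyond the scatter) gives a bound and not a size: the limit of > 10000 nM in this assay, at which 1 of the 4 values shown sits.

Open, from the compounds shown here alone, is whether the amide-free amino hydrogen matters, which a methylamino link would address. An ether oxygen or a methylene link at the same position would show whether any one-atom link behaves like (4-methylphenyl)amino.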